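The source may hold more compounds than are shown below. What is called first, only, known or untested is meant among the compounds shown, and "the series" means these compounds.

Measured compounds:
compound 1 `COc1ccc(Oc2ccccc2NC(C)=C2C(=O)CC(c3ccccc3)CC2=O)cc1`, 140 nM
compound 2 `CC(Nc1ccccc1Oc1cccc(N)c1)=C1C(=O)CC(c2ccccc2)CC1=O`, 53 nM
compound 3 `CC(Nc1ccccc1Oc1ccc(C(C)O)cc1)=C1C(=O)CC(c2ccccc2)CC1=O`, 58 nM

In a functional assay on L1210 cells (Mus musculus) for antiproliferative activity, read by cell counting, with a stated time of 96 h (on this read-out lower numbers stand for stronger inhibition and higher numbers for weaker inhibition), compound 2 gives the lowest of the three numbers; compound 3 sits within the scatter of it, as a 1.1-fold higher number from compound 2 to compound 3 (0.04 log units; within the scatter) shows, while compound 1 lies further off, by a 2.6-fold lower number from compound 1 to compound 2 (0.42 log units; beyond the scatter). The step to compound 4 `COc1ccc(Oc2ccccc2NC(C)=C2C(=O)CC(c3ccccc3)CC2=O)cc1OC` replaces the group on the ether oxygen: 3,4-dimethoxyphenyl in place of 3-aminophenyl on an oxygen on an aromatic ring. Going by the values given here, the one measured step that bears on this is the one from compound 1 to compound 2, where a 4-methoxyphenyl gave way to a 3-aminophenyl and the number fell by a 2.6-fold lower number from compound 1 to compound 2 (0.42 log units; beyond the scatter). Among the compounds with values here, compound 4 carries a 3,4-dimethoxyphenyl, which resembles the 4-methoxyphenyl of compound 1 with one methoxy added, so the step from compound 2 is expected to run the other way, back toward the number of compound 1, though no measured step covers the second methoxy. For compound 4 the estimate in this assay is 120 nM (range 50 nM to 300 nM), meaning an expected step of a 2.3-fold higher number from compound 2 to compound 4 (0.35 log units; beyond the scatter).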

Compound 4, half-maximal inhibitory concentration: 65 nM
The estimate for compound 4 lay 1.8-fold (0.27 log units) above the measured number, and the stated range covers the measured number.
By their numbers in this assay, from the lowest: compounds 2, 3 and 4 (each within the scatter of the next); then compound 1.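

In this assay, adding a methoxy to the 4-methoxyphenyl group of compound 1 is itself a step beyond the scatter (a 2.2-fold lower number from compound 1 to compound 4 (0.33 log units; beyond the scatter)), so a methoxy-only aryl group on the ether oxygen can reach the range of the amine and hydroxyethyl compounds. The 3,4-dimethoxyphenyl group, with 0 hydrogen-bond donors, stands level with both of those groups, as the steps within the scatter show (a 1.2-fold higher number from compound 2 to compound 4 (0.09 log units; within the scatter); a 1.1-fold higher number from compound 3 to compound 4 (0.05 log units; within the scatter)). No supporting measurement accounts for the shift produced by the second methoxy.

Among the compounds shown, it remains open whether a carboxylic acid, a fluorine or a longer alkoxy chain in place of the added methoxy would hold this level. On these data alone, all four compounds also share the same core, so it remains open whether these steps carry over to a different group on that core.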